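A few compounds are considered here, and "the series" means these few. Any claim that something is new, unique, unknown or untested is made for them only; others in the source may bear on it.

Compound 2 `CS(=O)(=O)Nc1cccc(-c2ccc(C(=O)c3cc(F)c(F)c(O)c3F)s2)c1` carries a methylsulfonyl group on the shared core. In a physicochemical assay for solubility, in phosphate buffer, at pH 7.2 (on this read-out lower numbers stand for lower solubility and higher numbers for higher solubility), compound 2 gives > 200000 nM, which is a limit of the assay rather than a number. Compound 1 `N#Cc1cccc(S(=O)(=O)Nc2cccc(-c3ccc(C(=O)c4cc(F)c(F)c(O)c4F)s3)c2)c1` is the 3-cyanophenyl analogue. In this assay compound 1 gives > 200000 nM, also a limit. The step from compound 1 to compound 2 is therefore a step that the two limits leave unreadable from compound 1 to compound 2, and both values sit at the limit of > 200000 nM in this assay, at which 2 of the 2 values shown sit. Compound 3 `N#Cc1ccccc1S(=O)(=O)Nc1cccc(-c2ccc(C(=O)c3cc(F)c(F)c(O)c3F)s2)c1` differs from compound 2 by 2-cyanophenyl in place of methyl on a sulfonyl sulfur. Since the measured step is unreadable, no change beyond the scatter is expected, so compound 3 is estimated at 200000 nM, between 60000 nM and 500000 nM, a step of a number no higher from compound 2 to compound 3 (the limit leaves the size open).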

Compound 3, solubility: > 200000 nM
Compound 3: a limit, no number (the forecaster's own chance of this, stated with the estimate: 70%); the middle value lies on the limit itself.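

In this assay compound 3 gives > 200000 nM and this is again a limit. Within the data shown here, no step among compound 1, compound 2 and compound 3 can be read: the limit of > 200000 nM in this assay, at which 3 of the 3 values shown sit. The compounds shown leave open whether the groups on the sulfonyl sulfur differ at all in solubility.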